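Cytotoxicity of Two Imines and an Unmeasured Analogue

The source may hold more compounds than are shown below. What is called first, only, known or untested is meant among the compounds shown, and "the series" means these compounds.

Compound 1 `Nc1sc2c(c1-c1nc3ccccc3s1)CCCC2`: 253 ug/mL
Compound 2 `Clc1ccc(/C=N/c2sc3c(c2-c2nc4ccccc4s2)CCC3)cc1`: 342 ug/mL

In an ADME assay on cells (Rhabdomyosarcoma cell, Homo sapiens) for cytotoxicity, read by MTT assay, with a stated time of 72 h (a lower number here means that less compound is tolerated, a higher number that more compound is tolerated), compound 2 gives 342 ug/mL, the higher of the two numbers, while compound 1 gives 253 ug/mL; the two sit within the scatter, so they show no real difference. Compound 3 `C(=C/c1ccccc1)\C=N\c1sc2c(c1-c1nc3ccccc3s1)CCC2` differs from compound 2 by 2-phenylethenyl in place of 4-chlorophenyl on a carbon with a double bond to nitrogen, the core otherwise unchanged. Among the measured compounds shown here, no measured pair shows this change, so no size of step can be read from the data; the expectation is a step no larger than the scatter, in either direction. Compound 3 is therefore expected to give 300 ug/mL, between 150 ug/mL and 600 ug/mL, a step of a 1.1-fold lower number from compound 2 to compound 3 (0.06 log units; within the scatter).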

Compound 3, half-maximal cytotoxic concentration: 122 ug/mL
Estimate against measurement, compound 3: 2.5-fold (0.39 log units) above; the measured number lies below the stated range.
By their numbers in this assay, from the lowest: compound 3; then compounds 1 and 2 (each within the scatter of the next).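

At this place, on a carbon with a double bond to nitrogen, the choice of group can change the result: in this assay, 2-phenylethenyl in place of 4-chlorophenyl gives a 2.8-fold lower number from compound 2 to compound 3 (0.45 log units; beyond the scatter), a modest step beyond the scatter. Less of compound 3 is therefore tolerated than of compound 2. No available evidence explains this step.

This single change replaces the chlorine-bearing ring with a ring carried on a double bond, so the two parts cannot be separated. Plain phenyl, or a longer saturated chain, at this place remains an open comparison.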